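Cytotoxicity of a Carboxymethyl Analogue Expected Unchanged

A few compounds are considered here, and "the series" means these few. Any claim that something is new, unique, unknown or untested is made for them only; others in the source may bear on it.

Within the data shown here, compound 2 `CCOC(=O)CCCCCOc1cccc(CN(C(=O)c2ccc(-c3cccc(Cl)c3)cc2)C(C)C)c1` is one of two compounds measured in an ADME assay on BJ cells (Homo sapiens) for cytotoxicity, read by CellTiter-Glo and resazurin assay, with a stated time of 72 h; on this read-out higher numbers stand for an effect only at larger amounts of compound and lower numbers for an effect already at smaller amounts. Its result in this assay is a limit of the assay rather than a number: compound 2 gives > 18400 nM. Compound 1 `CCOC(=O)CCCCCOc1cccc(CN(C(=O)c2ccc(-c3cccc(OC(F)(F)F)c3)cc2)C(C)C)c1` carries trifluoromethoxy where compound 2 carries chloro, and its result is also only a limit: compound 1 gives > 26000 nM. Among the measured compounds shown here, the step that the two limits leave unreadable from compound 1 to compound 2 therefore cannot be read, since the two limits the limit of > 18400 nM in this assay, at which 1 of the 2 values shown sits, and the limit of > 26000 nM in this assay, at which 1 of the 2 values shown sits, show only that neither compound reached a half-maximal effect within the tested range.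

Compound 3 `CCOC(=O)CCCCCOc1cccc(CN(C(=O)c2ccc(-c3cccc(CC(=O)O)c3)cc2)C(C)C)c1` differs from compound 2 by the change (carboxymethyl in place of chloro on an aromatic carbon). For the measured compounds named here, the only measured step in this assay offers no readable size, so nothing measured points to a step beyond the scatter in either direction, and the most that can be said is that both measured compounds stayed at their limits. Compound 3 is therefore expected to give about 30000 nM, within a range from 10000 nM to 100000 nM, most likely again reported as a limit. The step that the limit leaves unreadable from compound 2 to compound 3 is expected to lie within the scatter.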

Compound 3, half-maximal effective concentration: > 26000 nM
Compound 3: a limit, no number; the forecaster's own chance of this, stated with the estimate: 85%; the middle value does not contradict the limit.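

Among these compounds, compound 3, like compound 1 and compound 2, gives only a limit in this assay rather than a number, and no step among the three can be read. The compounds shown leave open whether exchanging these groups on the aromatic carbon changes cytotoxicity at all, and at what concentration a half-maximal effect would appear.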